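Methylation of the indole nitrogen in a weak pair

This account rests on a few compounds, and the source may have more. Where it says the series, first, only, none or still open, it means among the compounds named here.

Compound 2 `c1ccc2c(-c3coc(C4CCNCC4)n3)c[nH]c2c1`: 230000 nM
Compound 1 `Oc1ccc(-c2nc(-c3c[nH]c4ccccc34)co2)cc1`: 103000 nM

In a functional assay on MIA PaCa-2 cells (Homo sapiens) for cytotoxicity, read by MTT assay, with a stated time of 48 h (on this read-out lower numbers stand for stronger inhibition and higher numbers for weaker inhibition), compound 2 gives 230000 nM, the highest of the two numbers measured; its nearest neighbour is compound 1, which gives 103000 nM. Going by the values given here, the one step measured, a 2.2-fold higher number from compound 1 to compound 2 (0.35 log units; beyond the scatter), concerns the exchange of piperidin-4-yl for 4-hydroxyphenyl on an aromatic carbon and lies beyond the scatter.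

Compound 3 `Cn1cc(-c2coc(C3CCNCC3)n2)c2ccccc21` differs from compound 2 only by methyl in place of hydrogen on an aromatic nitrogen. Among the compounds with values here, no measured step bears on this change, so the shared core of compound 2 offers no precedent for it. Given that compound 2 already sits at the weak end, compound 3 is expected to show a step of a 1.1-fold higher number from compound 2 to compound 3 (0.04 log units; within the scatter) that stays within the scatter. The estimate for compound 3 in this assay is 250000 nM, with a range from 90000 nM to 700000 nM.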

Compound 3, half-maximal inhibitory concentration: 759000 nM
Estimate against measurement, compound 3: 3.0-fold (0.48 log units) below; measured number above the stated range.
By their numbers in this assay, from the lowest: compound 1; then compound 2; then compound 3.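

In this assay, methyl in place of hydrogen on the aromatic nitrogen weakens the compound, a change the earlier pair could not address: the result is a 3.3-fold higher number from compound 2 to compound 3 (0.52 log units; beyond the scatter). This position on the five-membered aromatic ring with 1 nitrogen therefore responds to even this single added carbon, and the number still moved upward although compound 2 had already stood at the weak end. Nothing available here explains the step.

Going by these compounds, whether the loss is particular to methyl or would follow any group on this nitrogen stays open, and an ethyl group or a 2-hydroxyethyl chain there would help to separate the two. Also open, on these data alone, is whether methyl at this position would have a similar effect in compound 1, which carries 4-hydroxyphenyl in place of piperidin-4-yl.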